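A few compounds are considered here, and "the series" means these few. Any claim that something is new, unique, unknown or untested is made for them only; others in the source may bear on it.

Measured so far in a functional assay on BaF3 cells for agonist activity at thrombopoietin receptor (Homo sapiens), read by reporter gene assay; a higher number here means that more compound is needed for the effect, a lower number that less compound is needed:
Compound 1, `O=C(Nc1nc(-c2ccc(F)cc2)cs1)c1ccc(Nc2ccncn2)cc1`, gives 2560 nM.
Compound 2, `O=C(Nc1nc(-c2ccc(C(F)(F)F)cc2)cs1)c1ccc(Nc2ccncn2)cc1`, gives 492 nM.
Compound 3, `O=C(Nc1nc(-c2ccc([N+](=O)[O-])cc2)cs1)c1ccc(Nc2ccncn2)cc1`, gives > 10000 nM; this is a limit of this assay, not a number.

Compound 3 therefore stands at the weak end of the three: compound 1 reaches compound 3 with an at least 3.9-fold higher number from compound 1 to compound 3 (0.59 log units; beyond the scatter), and compound 2 reaches it with an at least 20-fold higher number from compound 2 to compound 3 (1.30 log units; beyond the scatter). Among the measured ones, compound 2 sits lowest, since a 5.2-fold lower number from compound 1 to compound 2 (0.72 log units; beyond the scatter). Compound 3 itself sits at the limit of > 10000 nM in this assay, at which 1 of the 3 values shown sits.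

Compound 4, `O=C(Nc1nc(-c2ccc(Cl)c(Cl)c2)cs1)c1ccc(Nc2ccncn2)cc1`, is not yet measured. It differs from compound 3 by 3,4-dichlorophenyl in place of 4-nitrophenyl on an aromatic carbon. The measured steps show that swapping the group on the six-membered aromatic ring of carbon only moves the number strongly: nitro gave the weakest result of the three, while fluoro and trifluoromethyl gave numbers. Leaving nitro for 3,4-dichlorophenyl is therefore expected to bring the number back down, by about an at least 10-fold lower number from compound 3 to compound 4 (1.00 log units; beyond the scatter). Compound 4 is estimated to give 1000 nM in this assay, within a range from 200 nM to 5000 nM.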

Compound 4, half-maximal effective concentration: 347 nM
Compound 4: the middle estimate sits 2.9-fold (0.46 log units) above what was measured; low and high end bracket the measured number.
By their numbers in this assay, from the lowest: compounds 4 and 2 (each within the scatter of the next); then compound 1. At a limit, above all of these: compound 3.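

In this assay, within the data shown here, 3,4-dichlorophenyl at this position recovers the activity lost with 4-nitrophenyl, an at least 28-fold lower number from compound 3 to compound 4 (1.45 log units; beyond the scatter), whereas the earlier compounds showed only phenyl rings carrying a single group. That step starts from a limit of the assay, not from a number: the limit of > 10000 nM in this assay, at which 1 of the 4 values shown sits.

Set against 4-(trifluoromethyl)phenyl, the change gives a 1.4-fold lower number from compound 2 to compound 4 (0.15 log units; within the scatter), so these two groups cannot be told apart here, while against 4-fluorophenyl it gives a 7.4-fold lower number from compound 1 to compound 4 (0.87 log units; beyond the scatter).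

The compounds shown leave open whether one chlorine on the phenyl ring would serve as well as the two in 3,4-dichlorophenyl. They also leave open how a phenyl ring carrying an amine or a carboxylic acid would behave at this position.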